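Halogen swap on the pyrazoline series in paw edema

The source may report more compounds than this note shows. Statements on the series, on what has been measured and on what is new or still open speak of the compounds shown alone.

The series shares one core, carried by compound 1 `CC(=O)N1N=C(c2ccc(F)cc2)CC1c1cn(-c2ccccc2)nc1-c1ccc(Cl)c(Cl)c1`, compound 2 `CC(=O)N1N=C(c2ccc(Cl)cc2)CC1c1cn(-c2ccccc2)nc1-c1ccc(Cl)c(Cl)c1`, compound 3 `O=[N+]([O-])c1ccc(N2N=C(c3ccc(F)cc3)CC2c2cn(-c3ccccc3)nc2-c2ccc(Cl)c(Cl)c2)cc1` and the unmeasured compound 4 `O=[N+]([O-])c1ccc(N2N=C(c3ccc(Cl)cc3)CC2c2cn(-c3ccccc3)nc2-c2ccc(Cl)c(Cl)c2)cc1`. In a functional assay on the whole organism (strain Wistar) for inhibition, with Rattus norvegicus as the target, read by paw edema, with stated times of 30 min and 120 min, at a dose of 50 mg/kg by the oral route (a lower number here means less inhibition, a higher number more inhibition at the dose given (going by the name of the read-out)), compound 1 gives 72.7%, compound 2 gives 66.4% and compound 3 gives 65.6%; the three numbers sit close together and no order among them is claimed.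

Compound 2 differs from compound 1 by chloro in place of fluoro on an aromatic carbon, and this step reads a number 6.3 percentage points lower from compound 1 to compound 2 (within the scatter). Compound 3 differs from compound 1 by 4-nitrophenyl in place of acetyl on an amine nitrogen in a ring, with the step of a number 7.1 percentage points lower from compound 1 to compound 3 (within the scatter); this is also how the core of compound 3 differs from the core of compound 1. Compound 4 differs from compound 3 by chloro in place of fluoro on an aromatic carbon. Its place, on an aromatic carbon of a six-membered aromatic ring of carbon only, para to a large group, is word for word the place of the change from compound 1 to compound 2, so the two are the same change, made twice among the compounds shown.

The expected step of a number 5.6 percentage points lower from compound 3 to compound 4 (within the scatter) is set beside the measured step of a number 6.3 percentage points lower from compound 1 to compound 2 (within the scatter), which lies within the scatter, and it is likewise expected to stay within the scatter. For compound 4 the estimated value in this assay is 60%, with an expected range from 48% to 72%. For the measured compounds named here, the estimate rests on compound 3 giving 65.6% and on only one earlier instance of the change, so a wide band is kept.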

Compound 4, a percentage reported as inhibition, in the whole organism at one dose (the size of the read-out at that dose, not a potency): 69.5%
Compound 4: middle estimate off by 9.5 percentage points, on the low side; the range from low to high includes it.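

In this assay, chloro in place of fluoro on the core of compound 3 reads a number 3.9 percentage points higher from compound 3 to compound 4 (within the scatter), and this step does not separate from the earlier instance of the same change: the same change on two cores in this assay, a number 6.3 percentage points lower (within the scatter) from compound 1 to compound 2 and a number 3.9 percentage points higher (within the scatter) from compound 3 to compound 4, 10.2 percentage points apart, within the scatter of two such steps. The other change, 4-nitrophenyl in place of acetyl on an amine nitrogen in a ring, now carried out with the 4-chlorophenyl group in place, reads a number 3.1 percentage points higher from compound 2 to compound 4 (within the scatter), and it likewise does not separate from its earlier instance: the same change on two cores in this assay, a number 7.1 percentage points lower (within the scatter) from compound 1 to compound 3 and a number 3.1 percentage points higher (within the scatter) from compound 2 to compound 4, 10.2 percentage points apart, within the scatter of two such steps. Across these four compounds, neither change gives a step beyond the scatter on either core, which fits carrying each change across without a detectable dependence on the core, but it shows neither a fixed size or direction for either change nor that the changes act independently of each other.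

The compounds shown span only fluoro and chloro at this aromatic carbon and only acetyl and 4-nitrophenyl on the ring nitrogen, all at a single oral dose. Open, going by these compounds, is whether a group such as bromo, methoxy or trifluoromethyl on that ring, or a carboxylic acid or an amine on the group at the ring nitrogen, would give a step beyond the scatter.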